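From 2-methylphenyl to 3-hydroxyphenyl: working notes on the series

The source may hold more compounds than are shown below. What is called first, only, known or untested is meant among the compounds shown, and "the series" means these compounds.

- compound 1 `Clc1ccc(C[C@H]2COC[C@@H]2Cc2ccccc2)cc1Cl` in a functional assay on HL-60 cells (Homo sapiens) for cytotoxicity, read by WST assay, with a stated time of 48 h (on this read-out higher numbers stand for an effect only at larger amounts of compound and lower numbers for an effect already at smaller amounts), gives 19000 nM
- compound 2 `Cc1ccccc1C[C@H]1COC[C@@H]1Cc1ccc(Cl)c(Cl)c1` in this assay gives 21000 nM

For the measured compounds named here, compound 2 at 21000 nM lies within the scatter of compound 1, its only neighbour on the scale, so the two numbers set no order.

The next change leads to compound 3 `Oc1cccc(C[C@H]2COC[C@@H]2Cc2ccc(Cl)c(Cl)c2)c1` and puts 3-hydroxyphenyl in place of 2-methylphenyl on a saturated chain carbon bound to a saturated ring carbon.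

Going by the values given here, one measured step bears on this, the methyl in place of hydrogen on an aromatic carbon. That step is a 1.1-fold higher number from compound 1 to compound 2 (0.04 log units; within the scatter) (within the scatter), so the one variation of this aromatic ring measured so far left the number in this assay in place. Among the compounds with values here, no measured compound carries a hydroxyl, and the data give no direct reading on that group. No direction can therefore be argued, and the range has to stay wide on both sides.

The expected change is a 1.1-fold lower number from compound 2 to compound 3 (0.02 log units; within the scatter) (an estimate, with no step beyond the scatter foreseen). Compound 3 is expected at an estimated 20000 nM (range 8000 nM to 45000 nM).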

Compound 3, half-maximal effective concentration: 31000 nM
Estimate against measurement, compound 3: 1.6-fold (0.19 log units) below, and the stated range covers the measured number.
By their numbers in this assay, from the lowest: compounds 1, 2 and 3 (each within the scatter of the next).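

In this assay, for the compounds shown here, the change that brings a hydroxyl into the series, with the hydrogen-bond donor and acceptor counted for 3-hydroxyphenyl, gives a 1.5-fold higher number from compound 2 to compound 3 (0.17 log units; within the scatter) and so opens no step at this saturated chain carbon bound to a saturated ring carbon. The other route to compound 3, read on its own, gives a 1.6-fold higher number from compound 1 to compound 3 (0.21 log units; within the scatter), so neither route to compound 3 separates it from the other two compounds, and this aromatic ring has now carried both a methyl and a hydroxyl with no step beyond the scatter. Nothing measured on these compounds explains this flat reading.

On these data alone, whether an amine or a carboxylic acid on this aromatic ring, or a longer chain in place of the ring, would produce a step beyond the scatter remains open. The chlorine-bearing aromatic ring is the same in all three compounds, so the effect of replacing its chlorines, for example with methoxy groups, is also unknown.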